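The compounds below may be only part of what the source reports. "The series", "measured", "known", "first", "only" and "open" are said of these compounds alone.

Measured so far in a toxicity assay on HepG2 cells (Homo sapiens) for cytotoxicity, read by MTT assay, with a stated time of 72 h; a lower number here means that less compound is tolerated, a higher number that more compound is tolerated:

- compound 1 `CC(C)(C)Nc1nc2sc(-c3ccc(Cl)cc3)cc2c(=O)[nH]1`: 21400 nM
- compound 2 `CC(C)(C)Nc1nc2sc(-c3ccc(F)cc3)cc2c(=O)[nH]1`: a limit, > 25000 nM
- compound 3 `CC(C)(C)Nc1nc2cc(-c3ccc(Cl)cc3)oc2c(=O)[nH]1`: a limit, > 6250 nM

Compound 2 sits at the limit of > 25000 nM in this assay, at which 1 of the 3 values shown sits; compound 3 sits at the limit of > 6250 nM in this assay, at which 1 of the 3 values shown sits.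

Within this assay the change fluoro in place of chloro on an aromatic carbon gives an at least 1.1-fold higher number from compound 1 to compound 2 (0.06 log units; that floor lies within the scatter). How the core of compound 1 and the core of compound 3 differ is not broken down here.

Compound 4 `CC(C)(C)Nc1nc2cc(-c3ccc(F)cc3)oc2c(=O)[nH]1` is not yet measured. It carries the same change, (fluoro in place of chloro on an aromatic carbon), on the core of compound 3. The step is expected to be a step that the limit leaves unreadable from compound 3 to compound 4, because compound 1 to compound 2 showed an at least 1.1-fold higher number from compound 1 to compound 2 (0.06 log units; that floor lies within the scatter) and the change is made at the same place. Compound 4 is therefore expected to give about 20000 nM, with 8000 nM to 50000 nM as the expected range, and a limit rather than a number is likely.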

Compound 4, half-maximal cytotoxic concentration: > 3120 nM
Compound 4: no number, only a limit; the forecaster's own chance of this, stated with the estimate: 70%; the middle value lies beyond the limit too.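

Within the data shown here, compound 3 and compound 4 each give only a limit in this assay, so no step between them can be read. Open, on these data alone, is how far fluoro in place of chloro shifts tolerance on the core of compound 3.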